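The compounds below may be only part of what the source reports. "The series", "measured", "known", "first", "only" and "open" are said of these compounds alone.

Working notes on the series. In a functional assay on RS4-11 cells (Homo sapiens) for inhibition, read by CCK-8 assay, with a stated time of 48 h (on this read-out higher numbers stand for weaker inhibition and lower numbers for stronger inhibition), compound 1 `Nc1ccc(Oc2ccccc2-c2ccc(S(=O)(=O)NCCNC(=O)Nc3ccc(Cl)cc3)s2)cc1` gives 13600 nM. Compound 2 `O=C(NCCNS(=O)(=O)c1ccc(-c2ccccc2OCc2ccccc2)s1)Nc1cc(Cl)cc(Cl)c1` reaches only the limit of this assay, > 20000 nM, which is a limit and not a number; this is the point recorded as the limit of > 20000 nM in this assay, at which 1 of the 3 values shown sits. Compound 3 `Cc1ccc(-c2ccsc2S(=O)(=O)NCCNC(=S)Nc2ccc([N+](=O)[O-])cc2)c(Oc2ccc(O)c(O)c2)c1` gives 5100 nM in this assay, the lowest of the two numbers shown, and its gap to compound 1 lies beyond the usual scatter. Compound 4 `Cc1ccc(-c2ccsc2S(=O)(=O)NCCNC(=O)Nc2ccc([N+](=O)[O-])cc2)c(Oc2ccc(O)c(O)c2)c1` has not yet been measured in this assay. It differs from compound 3 in one place: a group of 12 heavy atoms (7 carbon, 2 nitrogen, 3 oxygen; one six-membered aromatic ring of carbon only) in place of a group of 12 heavy atoms (7 carbon, 2 nitrogen, 2 oxygen, 1 sulfur; one six-membered aromatic ring of carbon only), on an amine nitrogen. Going by the values given here, no pair of measured compounds differing in a single place is available, so the size of such a step has not been seen; compound 1 and compound 2 rest on other cores and give no direct guide. In this assay the step is expected to be small, in either direction and close to the scatter, estimated as a 1.6-fold higher number from compound 3 to compound 4 (0.20 log units; within the scatter). Compound 4 is therefore estimated at 8000 nM in this assay, within the range 3000 nM to 25000 nM.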

Compound 4, half-maximal inhibitory concentration: 7700 nM
The estimate for compound 4 lay 1.0-fold (0.02 log units) above the measured number; the range from low to high includes it.
By their numbers in this assay, from the lowest: compounds 3, 4 and 1 (each within the scatter of the next, the first and the last beyond it). At a limit, above all of these: compound 2.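

Going by these compounds alone, the pair gives the first direct reading of a single change: on an amine nitrogen whose other neighbour is a saturated chain carbon, (4-nitrophenyl)carbamoyl replaces a group of equal heavy-atom count that carries sulfur in place of one oxygen, and in this assay this gives a 1.5-fold higher number from compound 3 to compound 4 (0.18 log units; within the scatter). At this position, that exchange therefore leaves the read-out within the scatter, and no order can be drawn between the two compounds. Nothing measured here bears on why the step has this size.

As far as these compounds go, whether a different group on this amine nitrogen, such as an acetyl group or one carrying a carboxylic acid, would give a step beyond the scatter stays open. From the compounds shown here alone, compound 1 and compound 2 rest on other cores, so the part played by the rest of the structure also stays open.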